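This account rests on a few compounds, and the source may have more. Where it says the series, first, only, none or still open, it means among the compounds named here.

In a functional assay on NCI-H727 cells (Homo sapiens) for cytotoxicity, with a stated time of 48 h (on this read-out lower numbers stand for stronger inhibition and higher numbers for weaker inhibition), compound 1 (`COc1cc(OC)c(C(=O)/C=C/c2ccccc2OC)c(OC)c1`) gives 4000 nM and compound 2 (`COc1cc(OC)c(C(=O)/C=C/c2ccccc2)c(OC)c1`) gives 11400 nM, so compound 2 holds the higher of the two numbers. Compound 3 (`COc1cc(OC)c(C(=O)/C=C/c2ccc([N+](=O)[O-])cc2)c(OC)c1`) differs from compound 2 by one change: nitro in place of hydrogen on an aromatic carbon, para to a large group. Among the compounds with values here, only one measured step bears on this: a 2.9-fold higher number from compound 1 to compound 2 (0.45 log units; beyond the scatter), with hydrogen in place of methoxy on an aromatic carbon. Read in reverse, that modest step links a group in place of hydrogen with a lower number, but the group is a different one and no measured compound carries nitro. A modest step towards a lower number in this assay is therefore expected, though with little certainty. The expected step is a 1.9-fold lower number from compound 2 to compound 3 (0.28 log units; within the scatter). For compound 3 the estimated value is 6000 nM, with an expected range from 2000 nM to 16000 nM.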

Compound 3, half-maximal inhibitory concentration: 4100 nM
The estimate for compound 3 lay 1.5-fold (0.17 log units) above the measured number, within the range that was stated.
By their numbers in this assay, from the lowest: compounds 1 and 3 (each within the scatter of the next); then compound 2.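

In this assay, nitro in place of hydrogen on an aromatic carbon, para to a large group, gives a 2.8-fold lower number from compound 2 to compound 3 (0.44 log units; beyond the scatter), so a change at this position moves the number beyond the scatter. Alongside a 2.9-fold higher number from compound 1 to compound 2 (0.45 log units; beyond the scatter), where hydrogen replaces methoxy, this leaves compound 2, the only one of the three without a substituent on this ring, with the highest number, and the two groups that replace hydrogen, methoxy and nitro, both go with lower numbers. No measurement shown gives a reason for the step from hydrogen to nitro.

Going by these compounds, whether an amine, a carboxylic acid or a chlorine atom at this position would also lower the number remains open. So does whether nitro and methoxy together on the ring would add to each other.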